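The source may hold more compounds than are shown below. What is called first, only, known or untested is meant among the compounds shown, and "the series" means these compounds.

Of the compounds shown here, three sharing one core have been tested so far in a functional assay on A549 cells (Homo sapiens) for antiproliferative activity, read by MTT assay, with a stated time of 96 h; a lower number here means a stronger inhibitor, a higher number a weaker inhibitor. Compound 1 (`S=C(N/N=C1\CC2(CCCCC2)Oc2c1ccc1ccccc21)N1CCNCC1`) gives 12000 nM there, compound 2 (`S=C(N/N=C1\CC2(CCCCC2)Oc2c1ccc1ccccc21)N1CCOCC1`) gives 10100 nM and compound 3 (`S=C(CN1CCCCC1)N/N=C1\CC2(CCCCC2)Oc2c1ccc1ccccc21`) sits level with both at 10600 nM on this read-out. In compound 4 (`NCCCCCCC(=S)N/N=C1\CC2(CCCCC2)Oc2c1ccc1ccccc21`), 5-aminopentyl stands in place of piperidin-1-yl on a saturated chain carbon bound to a thiocarbonyl carbon (5-aminopentyl in place of piperidin-1-yl on a saturated chain carbon bound to a thiocarbonyl carbon). The measured swaps at this end of the molecule were small, namely a 1.2-fold lower number from compound 1 to compound 2 (0.07 log units; within the scatter) and a 1.1-fold lower number from compound 1 to compound 3 (0.05 log units; within the scatter) and a 1.0-fold higher number from compound 2 to compound 3 (0.02 log units; within the scatter) and all lay within the scatter. None of them replaced a ring with an open chain, so the guide is imperfect, yet no step beyond the scatter is expected in this assay here. The estimated step is a 1.2-fold lower number from compound 3 to compound 4 (0.07 log units; within the scatter) in expectation. Compound 4 is expected at 9000 nM (estimated range 4000 nM to 18000 nM).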

Compound 4, half-maximal inhibitory concentration: 3240 nM
The estimate for compound 4 lay 2.8-fold (0.44 log units) above the measured number; the measured number lies below the stated range.
By their numbers in this assay, from the lowest: compound 4; then compounds 2, 3 and 1 (each within the scatter of the next).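

The ring-bearing groups in compounds 1, 2 and 3 gave values within the scatter of one another, but this end of the molecule can still shift the number in this assay: swapping piperidin-1-yl for 5-aminopentyl gives a step beyond the scatter (a 3.3-fold lower number from compound 3 to compound 4 (0.51 log units; beyond the scatter)). The open chain of compound 4 also gives lower numbers than the other two ring groups (a 3.1-fold lower number from compound 2 to compound 4 (0.49 log units; beyond the scatter); a 3.7-fold lower number from compound 1 to compound 4 (0.57 log units; beyond the scatter)). No available measurement explains this gain.

The compounds shown cannot separate the effect of opening the ring from that of the chain's amine. A plain hexyl chain without an amine, or a longer aminoalkyl chain, would address that question.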